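Phenyl for Methyl on a Ring Nitrogen

A few compounds are considered here, and "the series" means these few. Any claim that something is new, unique, unknown or untested is made for them only; others in the source may bear on it.

Measured compounds:
- compound 1 `Cn1c(NC(=O)[C@@H]2CN(C(C)(C)C)C[C@H]2c2ccc(F)cc2F)nc2ccccc21` gives > 10000 nM in a functional assay for agonist activity at Melanocyte-stimulating hormone receptor (Homo sapiens), read by cAMP accumulation; on this read-out lower numbers stand for an effect already at smaller amounts and higher numbers for an effect only at larger amounts of compound
- compound 2 `CC(C)(C)N1C[C@@H](C(=O)Nc2ccccc2Cc2ccccc2)[C@H](c2ccc(F)cc2F)C1` gives > 10000 nM in this assay

Both compounds share a core that carries a tert-butyl group on a saturated nitrogen, a difluorophenyl group and an amide. On these data alone, for compound 1 the value is a limit of the assay, not a number, so its true potency is unknown beyond the statement that no half-maximal effect was reached at the amounts tested. The same holds for compound 2. This is summarised by the limit of > 10000 nM in this assay, at which 2 of the 2 values shown sit: neither compound shows a measurable effect in this assay.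

Compound 3 `CC(C)(C)N1C[C@@H](C(=O)Nc2nc3ccccc3n2-c2ccccc2)[C@H](c2ccc(F)cc2F)C1` has not yet been measured. It differs from compound 1 by phenyl in place of methyl on an aromatic nitrogen, in words: phenyl in place of methyl on an aromatic nitrogen. Among the measured compounds shown here, with no measured step between compounds to lean on, and with compound 1 itself sitting at a limit, there is no basis to expect a change beyond the scatter. Compound 3 is therefore expected to give about 10000 nM in this assay, within 2500 nM to 40000 nM, which means an estimated step of a number no higher from compound 1 to compound 3 (the limit leaves the size open).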

Compound 3, half-maximal effective concentration: > 10000 nM
Compound 3: only a limit was reported; the forecaster's own chance of this, stated with the estimate: 65%; the middle value lies on the limit itself.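

Among the compounds shown here, compound 1 and compound 3 each carry only a limit of the assay rather than a number, so no step between them can be read in this assay: the limit of > 10000 nM in this assay, at which 3 of the 3 values shown sit.

The compounds shown leave open whether phenyl in place of methyl on an aromatic nitrogen changes potency at all, and what on the shared core could bring a measurable effect in this assay at the amounts tested.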